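The source may report more compounds than this note shows. Statements on the series, on what has been measured and on what is new or still open speak of the compounds shown alone.

The series is read in a functional assay on A-375 cells (Homo sapiens), read by thymidine incorporation; a higher number here means a weaker inhibitor, a lower number a stronger inhibitor. Compound 1 `CCCCCCCCCCCCCCCCO[C@H]1O[C@H](COCC(CO)(CO)CO)[C@@H](O)[C@H](O)[C@H]1NC(=O)CCCC` gives 17 uM, compound 2 `CCCCCCCCCCCCCCCCO[C@H]1O[C@H](COC[C@H](O)CO)[C@@H](O)[C@H](O)[C@H]1NC(=O)CCCC` gives 2.2 uM, and compound 3 `CCCCCCCCCCCCCCCCO[C@H]1O[C@H](COCC(O)CO)[C@@H](O)[C@H](O)[C@H]1NC(=O)CCCC` gives 3 uM. Compound 3 stands level with compound 2, with a 1.4-fold higher number from compound 2 to compound 3 (0.13 log units; within the scatter). The sole difference between these two is the fact that one of compounds 2 and 3 is drawn with a defined configuration and the other without, at the place where they differ. Both sit well apart from compound 1, with a 7.7-fold lower number from compound 1 to compound 2 (0.89 log units; beyond the scatter) and a 5.7-fold lower number from compound 1 to compound 3 (0.75 log units; beyond the scatter).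

Compound 4 `CCCCCCCCCCCCCCCCO[C@H]1O[C@H](COCC(O)CO)[C@@H](O)[C@H](O)[C@H]1NC(=O)CCCCCCCCCCCCCCC` keeps the rest of compound 3 and changes the acyl chain: undecyl in place of hydrogen on a saturated chain carbon, four bonds along the chain from a carbonyl carbon. Among the compounds with values here, no measured step touches this chain, since all of them concern a different place in the molecule. They serve only as a gauge of size: a single change elsewhere was worth a 5.7-fold lower number from compound 1 to compound 3 (0.75 log units; beyond the scatter). A step of similar modest size is therefore expected, towards a higher number, though the direction is poorly supported. The expected step is a 2.7-fold higher number from compound 3 to compound 4 (0.43 log units; beyond the scatter). Compound 4 is estimated at 8 uM, with an expected range of 2.5 uM to 30 uM.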

Compound 4, concentration for 50% inhibition: 9.3 uM
Estimate against measurement, compound 4: 1.2-fold (0.07 log units) below, within the range that was stated.
By their numbers in this assay, from the lowest: compounds 2 and 3 (each within the scatter of the next); then compounds 4 and 1 (each within the scatter of the next).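

Extending the acyl chain, with undecyl in place of hydrogen on a saturated chain carbon, four bonds along the chain from a carbonyl carbon, gives a 3.1-fold higher number from compound 3 to compound 4 (0.49 log units; beyond the scatter) in this assay. This position is therefore not indifferent to chain length: the longer chain makes compound 4 a weaker inhibitor than compound 3, a modest change comparable in kind to the one at the other end of the molecule, a 5.7-fold lower number from compound 1 to compound 3 (0.75 log units; beyond the scatter). Nothing available bears on the cause of the step at the acyl chain.

On these data alone, two chain lengths define no trend, so it remains open whether an intermediate chain, or an acyl chain ending in an amine or a carboxylic acid, would read nearer compound 3 or compound 4. As far as these compounds go, it is also open whether the same extension has a similar effect alongside the side chain of compound 1.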